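The source may report more compounds than this note shows. Statements on the series, on what has been measured and on what is new or still open speak of the compounds shown alone.

Compound 2 `CCCCCCCCCCCCCCCCCC(=O)Nc1nnc(S[C@@H]2O[C@H](CO)[C@H](O)[C@H](O)[C@H]2O)s1` gives the lowest number of the three measured in a functional assay on HeLa cells (Homo sapiens) for cytotoxicity, read by MTT assay, with a stated time of 24 h (on this read-out lower numbers stand for stronger inhibition and higher numbers for weaker inhibition), at 11200 nM. Compound 3 `CCCCCCCCCCCCCCCC(=O)Nc1nnc(S[C@@H]2O[C@H](COC(C)=O)[C@H](OC(C)=O)[C@H](OC(C)=O)[C@H]2OC(C)=O)s1` gives 58300 nM, a higher number, and the gap to compound 2 lies beyond the scatter. Compound 1 `CCCCCCCCCCCCCCCCCC(=O)Nc1nnc(S[C@@H]2O[C@H](COC(C)=O)[C@H](OC(C)=O)[C@H](OC(C)=O)[C@H]2OC(C)=O)s1` gives 97500 nM, a still higher number, and its gap to compound 2 also lies beyond the scatter. Compound 4 `CCCCCCCCCCCCCCCC(=O)Nc1nnc(S[C@@H]2O[C@H](CO)[C@H](O)[C@H](O)[C@H]2O)s1` has not yet been measured. It differs from compound 2 by hydrogen in place of ethyl on a saturated chain carbon, ten or more bonds along the chain from a carbonyl carbon. For the measured compounds named here, one measured step bears on this, the same change made between two other compounds: a 1.7-fold lower number from compound 1 to compound 3 (0.22 log units; within the scatter). Because that step a 1.7-fold lower number from compound 1 to compound 3 (0.22 log units; within the scatter) stayed within the scatter, only a small shift, if any, is expected in this assay here. Compound 4 is therefore estimated at 8000 nM, with a range from 3500 nM to 18000 nM. This expected step, a 1.4-fold lower number from compound 2 to compound 4 (0.15 log units; within the scatter), is anticipated to remain within the scatter.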

Compound 4, half-maximal inhibitory concentration: 14200 nM
For compound 4 the middle estimate is 1.8-fold (0.25 log units) below the measured one; the range from low to high includes it.
By their numbers in this assay, from the lowest: compounds 2 and 4 (each within the scatter of the next); then compounds 3 and 1 (each within the scatter of the next).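

In this assay, hydrogen in place of ethyl on this saturated chain carbon gives a 1.3-fold higher number from compound 2 to compound 4 (0.10 log units; within the scatter), so the change stays within the scatter on the core of compound 2 as well as on the core of compound 1. Read together, the change behaves alike on both cores: the same change on two cores in this assay, a 1.7-fold lower number (0.22 log units; within the scatter) from compound 1 to compound 3 and a 1.3-fold higher number (0.10 log units; within the scatter) from compound 2 to compound 4, 2.1-fold (0.33 log units) apart, within the scatter of two such steps

Only this one shortening of the chain is shown, so the tolerance cannot be extended to larger changes. From the compounds shown here alone, whether a much shorter chain such as butyl, a longer chain, or an amine on the chain would move the number stays open.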